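Adding a second 3-methylbut-2-en-1-yl group

This account rests on a few compounds, and the source may have more. Where it says the series, first, only, none or still open, it means among the compounds named here.

Measured so far in a functional assay on A549 cells (Homo sapiens) for inhibition, read by MTT assay, with a stated time of 72 h; on this read-out lower numbers stand for stronger inhibition of growth and higher numbers for weaker inhibition of growth:
- Compound 1 `CC(C)=CC(=O)NC(=N)NC(=O)C=C(C)C` gives 75600 nM
- Compound 2 `CC(C)=CCC/C(C)=C/C(=O)NC(=N)NC(=O)C=C(C)C` gives 37400 nM

Compound 2 holds the lower of these two numbers, so it is the stronger growth inhibitor of the pair. Compound 3 `CC(C)=CCC/C(C)=C/C(=O)NC(=N)NC(=O)/C=C(\C)CCC=C(C)C` comes from compound 2 through one change: 3-methylbut-2-en-1-yl in place of hydrogen on a saturated chain carbon bound to a double-bonded chain carbon. Among the measured compounds shown here, only one measured step bears on this, the same swap, which gave a 2.0-fold lower number from compound 1 to compound 2 (0.31 log units; beyond the scatter). This modest step is thin evidence, but a similar lowering is expected in this assay. The expected size is a 2.0-fold lower number from compound 2 to compound 3 (0.29 log units; within the scatter). Compound 3 is estimated at 19000 nM, within a range from 8000 nM to 40000 nM.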

Compound 3, concentration for 50% growth inhibition: 46900 nM
Estimate against measurement, compound 3: 2.5-fold (0.39 log units) below; the whole stated range lies below it.
By their numbers in this assay, from the lowest: compounds 2, 3 and 1 (each within the scatter of the next, the first and the last beyond it).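

In this assay the same swap, made a second time, gives a 1.3-fold higher number from compound 2 to compound 3 (0.10 log units; within the scatter) rather than the step of a 2.0-fold lower number from compound 1 to compound 2 (0.31 log units; beyond the scatter) seen with the first such group. So among these three compounds, the gain does not build up: a second 3-methylbut-2-en-1-yl group brings no change that stands clear of the scatter. Nothing measured here explains this difference between the two steps.

On these data alone, it remains open whether a longer chain, an amine or a carboxylic acid on this saturated chain carbon would change the number in this assay beyond the scatter.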